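Swapping the Aryl Ketone: From Compound 3 to Compound 4

This account rests on a few compounds, and the source may have more. Where it says the series, first, only, none or still open, it means among the compounds named here.

Compound 1 `Nc1scc(CN2CCN(c3cc(Cl)cc(Cl)c3)CC2)c1C(=O)c1ccc(Cl)cc1` gives -69% in a functional assay on CHO cells with adenosine receptor A1 (Homo sapiens) as the target, read by cAMP accumulation and immunoassay, with a stated time of 6 min, tested at 1 uM; a higher number here means a weaker effect of the compound at the concentration tested, a lower number a stronger effect.
Compound 2 `Nc1scc(CN2CCN(c3ccc(Cl)cc3F)CC2)c1C(=O)c1ccc(Cl)cc1` gives -57% in this assay.
Compound 3 `Nc1scc(CN2CCN(c3cccc(F)c3)CC2)c1C(=O)c1cccc(C(F)(F)F)c1` gives -35% in this assay.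

Compound 3 stands highest of the three in this assay, meaning the weakest effect; its gaps to compound 2 and to compound 1 both lie beyond the scatter. Compound 4 `Nc1scc(CN2CCN(c3cccc(F)c3)CC2)c1C(=O)c1ccc(Cl)cc1` differs from compound 3 by 4-chlorophenyl in place of 3-(trifluoromethyl)phenyl on a carbonyl carbon. Within the data shown here, the only measured step, a number 12 percentage points higher from compound 1 to compound 2 (beyond the scatter), changes the group on the amine nitrogen in a ring, not the group on the carbonyl carbon, so no measured step bears directly on this change. Compounds 1 and 2 carry the entering 4-chlorophenyl and both give lower numbers than compound 3, yet they also differ from compound 3 elsewhere, so the size is uncertain. Compound 4 is expected at -50%, from -70% to -30%. The expected step is a number 15 percentage points lower from compound 3 to compound 4 (beyond the scatter), toward a stronger effect.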

Compound 4, a percentage reported as activity, at one concentration (the size of the read-out at that concentration, not a potency): -86%
Beside the measured number, compound 4's estimate is 36 percentage points above it, and the stated range ends above it.
By their numbers in this assay, from the lowest: compound 4; then compound 1; then compound 2; then compound 3.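

On the carbonyl carbon, 4-chlorophenyl in place of 3-(trifluoromethyl)phenyl produces a large change in this assay (a number 51 percentage points lower from compound 3 to compound 4 (beyond the scatter)), so this position matters a great deal. With 4-chlorophenyl held there, 3-fluorophenyl on the amine nitrogen also gives a lower number than either 4-chloro-2-fluorophenyl (a number 29 percentage points lower from compound 2 to compound 4 (beyond the scatter)) or 3,5-dichlorophenyl (a number 17 percentage points lower from compound 1 to compound 4 (beyond the scatter)). No available evidence explains either shift.

Still open, going by these compounds, is how a pyridine ring or a plain alkyl chain on the carbonyl carbon would compare with 4-chlorophenyl.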